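The source may hold more compounds than are shown below. What is called first, only, known or untested is meant among the compounds shown, and "the series" means these compounds.

Compounds measured so far:
- compound 1 `COc1ccc(Nc2cc(-c3ccccc3)oc(=O)c2)cc1`: 0.16 uM in a functional assay on KB cells (Homo sapiens) for cytotoxicity, read by MTT assay, with a stated time of 72 h; on this read-out lower numbers stand for an effect already at smaller amounts and higher numbers for an effect only at larger amounts of compound
- compound 2 `COc1ccc(Nc2cc(C)oc(=O)c2)cc1`: in this assay compound 2 gives only a limit, > 30 uM

Compound 2 therefore stands at the limit of this assay, as the limit of > 30 uM in this assay, at which 1 of the 2 values shown sits, shows, and no number is known for it. Compound 3 `CCCCCc1cc(Nc2ccc(OC)cc2)cc(=O)o1` differs from compound 2 in one place: butyl in place of hydrogen on a saturated chain carbon bound to an aromatic carbon. For the measured compounds named here, only one measured step touches this position on the core: an at least 180-fold higher number from compound 1 to compound 2 (2.27 log units; beyond the scatter). Going by the values given here, that step shows that what sits on this aromatic carbon governs the read-out strongly, but no measured pair tells how a pentyl chain compares with a methyl or a phenyl there. Since compound 1 reaches 0.16 uM with a phenyl in this place, some recovery for compound 3 is expected, though a smaller one than the full step back. Compound 3 is therefore expected to show an at least 3.7-fold lower number from compound 2 to compound 3 (0.57 log units; beyond the scatter), giving an estimated 8 uM with a range from 1.5 uM to 40 uM.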

Compound 3, concentration for half-maximal effect: 10.1 uM
For compound 3 the middle estimate is 1.3-fold (0.10 log units) below the measured one; measured number inside the range.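

In this assay, going from the methyl of compound 2 to the pentyl of compound 3 gives an at least 2.9-fold lower number from compound 2 to compound 3 (0.47 log units; beyond the scatter), which shows that a saturated chain on this aromatic carbon can restore a measurable effect without any ring in that place. The chain does not match the phenyl, however, as a 63-fold higher number from compound 1 to compound 3 (1.80 log units; beyond the scatter) shows, so the phenyl of compound 1 remains far ahead of both other groups tried here. The size of the step from the methyl to the pentyl has only a lower bound, as compound 2 gives a limit and no number: the limit of > 30 uM in this assay, at which 1 of the 3 values shown sits.

The compounds shown leave open how the read-out changes along the chains between methyl and pentyl, and whether a longer chain such as heptyl would narrow the remaining gap to the phenyl. They also leave open how a cyclohexyl or a benzyl group would compare in this place.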